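This account rests on a few compounds, and the source may have more. Where it says the series, first, only, none or still open, it means among the compounds named here.

Measured compounds in an assay on isolated protein for displacement of a labelled ligand from metabotropic glutamate receptor 5 (Homo sapiens), with a stated time of 60 min, tested at 1 uM; on this read-out lower numbers stand for less inhibition and higher numbers for more inhibition at the one concentration tested (going by the name of the read-out):
- compound 1 `Cc1ccc(S(=O)(=O)c2cnc3ccc(F)cc3c2N2CCC(C)CC2)cc1C` gives 92%
- compound 2 `COc1ccc(S(=O)(=O)c2cnc3ccc(F)cc3c2N2CCC(C)CC2)cc1Cl` gives 82%
- compound 3 `CC1CCN(c2c(S(=O)(=O)c3ccc(Cl)c(Cl)c3)cnc3ccc(F)cc23)CC1` gives 91%

On these numbers compound 3 is separated from its neighbours only by gaps within the scatter: a number 1 percentage points lower from compound 1 to compound 3 (within the scatter) and a number 9 percentage points higher from compound 2 to compound 3 (within the scatter). Compound 4 `CC1CCN(c2c(S(=O)(=O)c3cc(Cl)cc(Cl)c3)cnc3ccc(F)cc23)CC1` has not been measured in this assay. It differs from compound 3 in one place: 3,5-dichlorophenyl in place of 3,4-dichlorophenyl on a sulfonyl sulfur. Within the data shown here, no measured step rearranges substituents on the aryl attached to the sulfonyl sulfur; the closest comparisons are the aryl exchanges a number 1 percentage points lower from compound 1 to compound 3 (within the scatter) and a number 10 percentage points lower from compound 1 to compound 2 (within the scatter), both within the scatter. For this assay a step within the scatter is therefore expected, a number 3 percentage points lower from compound 3 to compound 4 (within the scatter). Compound 4 is estimated at 88%, with a range from 75% to 96%.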

Compound 4, a percentage reported as inhibition, at one concentration (the size of the read-out at that concentration, not a potency): 69%
Beside the measured number, compound 4's estimate is 19 percentage points above it; measured number below the stated range.
By their numbers in this assay, from the lowest: compound 4; then compounds 2, 3 and 1 (each within the scatter of the next).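

In this assay, among these compounds, the aryl on the sulfonyl sulfur responds to the arrangement of its substituents as well as to their identity: with the same atoms, 3,5-dichlorophenyl in place of 3,4-dichlorophenyl gives a number 22 percentage points lower from compound 3 to compound 4 (beyond the scatter) and is the first step beyond the scatter. The 3,5-dichlorophenyl group also stands apart from the other two aryl groups, with a number 13 percentage points lower from compound 2 to compound 4 (beyond the scatter) and a number 23 percentage points lower from compound 1 to compound 4 (beyond the scatter) as the steps.

As far as these compounds go, whether 3-chlorophenyl or 4-chlorophenyl, each with a single chlorine, would keep the inhibition of compound 3 stays open. Nothing available explains the drop.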